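This account rests on a few compounds, and the source may have more. Where it says the series, first, only, none or still open, it means among the compounds named here.

Working notes on the series. Compound 1 `CCN(CC)CCCNc1nc(-c2ccc(NC(=O)Nc3ccc(F)cc3)cc2)nc2ccsc12` and compound 2 `CCN(CC)CCCNc1nc(-c2ccc(NC(=O)Nc3ccccc3F)cc2)nc2ccsc12` differ only in the group on the amide-type nitrogen. In a functional assay on HT-29 cells (Homo sapiens) for cytotoxicity, read by MTT assay, with a stated time of 72 h (a lower number here means a stronger inhibitor, a higher number a weaker inhibitor), compound 1 gives 340 nM and compound 2 gives 550 nM; the step of a 1.6-fold higher number from compound 1 to compound 2 (0.21 log units; within the scatter) lies within the scatter. Compound 2 thus stands at the top of the two numbers, though its gap to compound 1 is within the scatter. Compound 3 `CCN(CC)CCCNc1nc(-c2ccc(NC(=O)Nc3ccc(C)cc3)cc2)nc2ccsc12` carries the change (4-methylphenyl in place of 2-fluorophenyl on an amide-type nitrogen). Within the data shown here, no measured step covers this exchange; the one step known is within the scatter. The expected step is therefore a 1.2-fold lower number from compound 2 to compound 3 (0.09 log units; within the scatter), none beyond the scatter. For compound 3 the estimate in this assay is 450 nM, with a range of 150 nM to 1400 nM.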

Compound 3, half-maximal inhibitory concentration: 1620 nM
Compound 3: middle estimate off by 3.6-fold (0.56 log units), on the low side, outside the stated range (above it).
By their numbers in this assay, from the lowest: compounds 1 and 2 (each within the scatter of the next); then compound 3.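

In this assay, the group on the amide-type nitrogen now makes a difference beyond the scatter: a 2.9-fold higher number from compound 2 to compound 3 (0.47 log units; beyond the scatter), and a 4.8-fold higher number from compound 1 to compound 3 (0.68 log units; beyond the scatter). The second step is the cleaner reading, with methyl in place of fluoro on an aromatic carbon, whereas the 2-fluorophenyl and 4-fluorophenyl compounds stayed within the scatter of each other. Nothing available explains the size of these steps.

Still open, as far as these compounds go, is whether this weakening is particular to methyl or also appears with chloro, methoxy or an amine at the same place on the ring.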